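Nitro for Methyl on the Aryl Ring of Compound 2

A few compounds are considered here, and "the series" means these few. Any claim that something is new, unique, unknown or untested is made for them only; others in the source may bear on it.

Compound 1 `CCCS(=O)(=O)Nc1ccc(F)c(C(=O)c2n[nH]c3ncc(-c4ccccc4C)cc23)c1F` gives 7% in an assay for binding affinity to dual specificity mitogen-activated protein kinase kinase 4 (Homo sapiens), read by KINOMEscan, tested at 100 nM; a higher number here means a weaker effect of the compound at the concentration tested, a lower number a stronger effect. Compound 2 `CCCS(=O)(=O)Nc1ccc(F)c(C(=O)c2n[nH]c3ncc(-c4cccc(C)c4)cc23)c1F` gives 15%. Compound 3 `CCCS(=O)(=O)Nc1ccc(F)c(C(=O)c2n[nH]c3ncc(-c4ccccc4N)cc23)c1F` gives 23%.

Compound 2 stands second highest of the three, with a number 8 percentage points higher from compound 1 to compound 2 (within the scatter) and a number 8 percentage points higher from compound 2 to compound 3 (within the scatter). Compound 4 `CCCS(=O)(=O)Nc1ccc(F)c(C(=O)c2n[nH]c3ncc(-c4cccc([N+](=O)[O-])c4)cc23)c1F` differs from compound 2 by nitro in place of methyl on an aromatic carbon. Within the data shown here, no measured step makes this exact change. The closest is a number 16 percentage points higher from compound 1 to compound 3 (beyond the scatter), which also replaces a methyl on an aromatic carbon; the two steps leaving compound 2 both stay within the scatter. For compound 4 a small rise in this assay is therefore expected, estimated as a number 7 percentage points higher from compound 2 to compound 4 (within the scatter), most likely within the scatter. Compound 4 is expected at 22%, within 8% to 42%.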

Compound 4, a percentage reported as activity, at one concentration (the size of the read-out at that concentration, not a potency): 15%
Compound 4: middle estimate off by 7 percentage points, on the high side; the measured number falls inside the stated range.
By their numbers in this assay, from the lowest: compounds 1, 2, 4 and 3 (each within the scatter of the next, the first and the last beyond it).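

In this assay, the step from the 3-methylphenyl to the 3-nitrophenyl group gives no change at the digits printed from compound 2 to compound 4 (within the scatter), so at this place on the ring nitro, with its three heavy atoms and two hydrogen-bond acceptors, stands in for methyl with no shift beyond the scatter. The other two steps also stay within the scatter, with a number 8 percentage points higher from compound 1 to compound 4 (within the scatter) and a number 8 percentage points lower from compound 3 to compound 4 (within the scatter). Nothing at hand bears on why nitro and methyl read alike here.

On these data alone, whether an amine, a carboxylic acid or a longer chain at this same place would also stay within the scatter of compound 2 remains open.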